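This account rests on a few compounds, and the source may have more. Where it says the series, first, only, none or still open, it means among the compounds named here.

Series notes. Compound 1 `COc1cc(C(=O)c2ccc3c(ccn3S(=O)(=O)c3ccc(/C=C/C(=O)NO)cc3)c2)cc(OC)c1OC` carries a 3,4,5-trimethoxyphenyl on a carbonyl carbon; in an assay on isolated protein for inhibition of protein deacetylase HDAC6 (Homo sapiens) (a higher number here means a weaker inhibitor, a lower number a stronger inhibitor), compound 1 gives 972 nM. Compound 2 `COc1ccc(C(=O)c2ccc3c(ccn3S(=O)(=O)c3ccc(/C=C/C(=O)NO)cc3)c2)cc1` differs by 4-methoxyphenyl in place of 3,4,5-trimethoxyphenyl on a carbonyl carbon; in this assay compound 2 gives 848 nM, and the step of a 1.1-fold lower number from compound 1 to compound 2 (0.06 log units; within the scatter) is within the scatter. Compound 3 `COc1cc(C(=O)c2ccc3c(ccn3Cc3ccc(/C=C/C(=O)NO)cc3)c2)cc(OC)c1OC` has a different core from compound 1; the difference between the two cores is not broken down here. In this assay compound 3 gives 143 nM, the lowest number of the three. Compound 4 `COc1ccc(C(=O)c2ccc3c(ccn3Cc3ccc(/C=C/C(=O)NO)cc3)c2)cc1` is compound 3 with 4-methoxyphenyl in place of 3,4,5-trimethoxyphenyl on a carbonyl carbon, the same change as from compound 1 to compound 2, at a place described identically. Because a 1.1-fold lower number from compound 1 to compound 2 (0.06 log units; within the scatter) lies within the scatter, the step of a 1.1-fold lower number from compound 3 to compound 4 (0.04 log units; within the scatter) is expected to be small as well. For compound 4 in this assay the estimate is 130 nM, between 60 nM and 300 nM.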

Compound 4, half-maximal inhibitory concentration: 108 nM
The estimate for compound 4 lay 1.2-fold (0.08 log units) above the measured number; low and high end bracket the measured number.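

In this assay, 4-methoxyphenyl in place of 3,4,5-trimethoxyphenyl on a carbonyl carbon gives a 1.3-fold lower number from compound 3 to compound 4 (0.12 log units; within the scatter), so the change stays small on the second core as well. The two steps agree across the cores: the same change on two cores in this assay, a 1.1-fold lower number (0.06 log units; within the scatter) from compound 1 to compound 2 and a 1.3-fold lower number (0.12 log units; within the scatter) from compound 3 to compound 4, 1.2-fold (0.06 log units) apart, within the scatter of two such steps

This shows that, for these two cores, the small size of the step carries from one to the other; it does not show a real direction for the change, as both steps lie within the scatter, and two cores say nothing about any further core.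

Open, on these data alone, is whether an amine or a carboxylic acid in place of the methoxy groups would shift the number on either core. Also open, as far as these compounds go, is whether a larger change at this place would carry across the cores as closely.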